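This account rests on a few compounds, and the source may have more. Where it says the series, first, only, none or still open, it means among the compounds named here.

The measured compounds, both read in a functional assay on MOLM-13 cells (Homo sapiens) for cytotoxicity, read by MTT assay, with a stated time of 48 h; on this read-out lower numbers stand for an effect already at smaller amounts and higher numbers for an effect only at larger amounts of compound:

Compound 1 `Cc1c(O)c(=O)ccn1CC(=O)N/N=C1\C(=O)N(CC(=O)Nc2ccc(Br)cc2)c2ccccc21`: 1170 nM
Compound 2 `Cc1c(O)c(=O)ccn1CC(=O)N/N=C1\C(=O)N(CC(=O)Nc2ccc(Cl)cc2Cl)c2ccccc21`: 1620 nM

For the measured compounds named here, compound 1 is one of only two compounds measured in this assay. Going by the values given here, its sole neighbour is compound 2, and the step of a 1.4-fold higher number from compound 1 to compound 2 (0.14 log units; within the scatter) is within the scatter, so the two numbers cannot be told apart on this read-out.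

Compound 3 `Cc1c(O)c(=O)ccn1CC(=O)N/N=C1\C(=O)N(CC(=O)Nc2cc(Cl)cc(Cl)c2)c2ccccc21` is not yet measured. It differs from compound 1 by 3,5-dichlorophenyl in place of 4-bromophenyl on an amide-type nitrogen. Among the compounds with values here, the one step that bears on this change is the one from compound 1 to compound 2, in which a dichlorophenyl group also replaced the 4-bromophenyl group on the same amide-type nitrogen, though with a different substitution pattern; that step, a 1.4-fold higher number from compound 1 to compound 2 (0.14 log units; within the scatter), lay within the scatter. Nothing in the two measured compounds points to a step beyond the scatter for a second dichlorophenyl variant, so no change beyond the scatter is expected in this assay.

Compound 3 is therefore estimated at 1400 nM, with a range from 700 nM to 2800 nM, which means an expected step of a 1.2-fold higher number from compound 1 to compound 3 (0.08 log units; within the scatter).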

Compound 3, half-maximal effective concentration: 690 nM
Compound 3: the middle estimate sits 2.0-fold (0.31 log units) above what was measured; measured number below the stated range.
By their numbers in this assay, from the lowest: compounds 3, 1 and 2 (each within the scatter of the next, the first and the last beyond it).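

In this assay, for the compounds shown here, 3,5-dichlorophenyl in place of 2,4-dichlorophenyl on the amide-type nitrogen gives a 2.3-fold lower number from compound 2 to compound 3 (0.37 log units; beyond the scatter), a modest change and the only step at this position so far that lies beyond the scatter, so two dichlorophenyl groups with the same atoms can be told apart here. The replacement of 4-bromophenyl by 3,5-dichlorophenyl, by contrast, gives a 1.7-fold lower number from compound 1 to compound 3 (0.23 log units; within the scatter), which leaves compound 3 and compound 1 indistinguishable on this read-out, even though the step to compound 3 from compound 2 can be read. No measurement at hand accounts for the difference between the two dichlorophenyl groups.

On these data alone, all three compounds carry a halogen-bearing phenyl group at this position, so it remains open whether an unsubstituted phenyl, a methoxyphenyl, a pyridyl ring or a simple alkyl chain on the same nitrogen would stay within the scatter of compound 3 or move beyond it. As far as these compounds go, it is also open whether the gap between the two dichlorophenyl groups would persist with a different core or in cells other than those tested here.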